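The compounds below may be only part of what the source reports. "The series", "measured", "known", "first", "only" and "open" are said of these compounds alone.

Measured so far:
Compound 1 `COc1ccc(CNc2nc([SeH])nc3ccccc23)cc1` in a functional assay on HT-29 cells (Homo sapiens) for cytotoxicity, read by MTT assay, with a stated time of 72 h (a higher number here means a weaker inhibitor of growth, a lower number a stronger inhibitor of growth), gives > 100000 nM, a limit of the assay.
Compound 2 `[SeH]c1nc(NCc2ccccc2)c2cccnc2n1` in this assay gives 33100 nM.
Compound 3 `[SeH]c1nc(NCc2ccccc2)c2ccccc2n1` in this assay gives > 100000 nM, again a limit of the assay.

Compound 3 stands at the assay limit (the limit of > 100000 nM in this assay, at which 2 of the 3 values shown sit). For the measured compounds named here, the only step between measured compounds, a step that the two limits leave unreadable from compound 1 to compound 3, joins two limits and its size cannot be read. Compound 4 `C[Se]c1nc(NCc2ccccc2)c2ccccc2n1` differs from compound 3 by methyl in place of hydrogen on a selenium. Going by the values given here, no measured step involves the selenium, so none of the measured compounds bears on this change, and no direction beyond the scatter is expected for it in this assay. Compound 4 is therefore expected to remain at or near the limit, estimated at 100000 nM with a range of 30000 nM to 300000 nM. The expected step is a number no higher from compound 3 to compound 4 (the limit leaves the size open).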

Compound 4, concentration for total growth inhibition: 81000 nM
Compound 4: the middle estimate sits 1.2-fold (0.09 log units) above what was measured; low and high end bracket the measured number.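

The selenium position now has its first step: methyl in place of hydrogen on a selenium gives an at least 1.2-fold lower number from compound 3 to compound 4 (0.09 log units; that floor lies within the scatter) in this assay. Compound 4 gives a readable number, 81000 nM. This methyl on the selenium brings the series off the limit without any shift shown to lie beyond the scatter. The true size of the step stays open, since it starts from a limit: the limit of > 100000 nM in this assay, at which 2 of the 4 values shown sit.

Open, on these data alone, is whether a longer chain or a carboxylic acid on the selenium would move the number further. Also open, as far as these compounds go, is how methyl on the selenium behaves on the core of compound 2.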